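The compounds below may be only part of what the source reports. "The series", "measured", "known", "first", "only" and "open" are said of these compounds alone.

Compound 1 `Cc1ccc(-c2csc(NC(=O)COc3ccccc3C)n2)cc1` and compound 3 `Cc1ccccc1OCC(=O)Nc1nc(-c2ccc(Cl)cc2)cs1` share a core and differ only by chloro in place of methyl on an aromatic carbon. In a functional assay on MDA-MB-468 cells (Homo sapiens) for cytotoxicity, read by trypan blue exclusion, with a stated time of 48 h (on this read-out lower numbers stand for stronger inhibition and higher numbers for weaker inhibition), compound 1 gives 51700 nM, and compound 3 gives 52100 nM; the two are a 1.0-fold higher number from compound 1 to compound 3 (0.00 log units; within the scatter). Compound 2 `Cc1ccc(-c2csc(NC(=O)COc3ccc(F)cc3F)n2)cc1` carries the change 2,4-difluorophenyl in place of 2-methylphenyl on an oxygen on a saturated carbon relative to compound 1, and in this assay compound 2 gives 10200 nM, which is a 5.1-fold lower number from compound 1 to compound 2 (0.70 log units; beyond the scatter). Compound 4 `O=C(COc1ccc(F)cc1F)Nc1nc(-c2ccc(Cl)cc2)cs1` is not yet measured; it stands to compound 3 as compound 2 stands to compound 1, differing by 2,4-difluorophenyl in place of 2-methylphenyl on an oxygen on a saturated carbon, and the place of the change is the same in both pairs, so it is the same change, seen twice among these four compounds. Compound 4 is expected to move by about a 4.7-fold lower number from compound 3 to compound 4 (0.68 log units; beyond the scatter) in this assay, beside the earlier step, because that earlier step measured a 5.1-fold lower number from compound 1 to compound 2 (0.70 log units; beyond the scatter) and compound 3 starts from 52100 nM, a level matching compound 1. On that basis compound 4 is estimated at 11000 nM in this assay, with a likely range from 4000 nM to 30000 nM, resting on a single prior instance of the change.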

Compound 4, half-maximal inhibitory concentration: 32300 nM
Compound 4: the middle estimate sits 2.9-fold (0.47 log units) below what was measured; the whole stated range lies below it.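

In this assay the change to 2,4-difluorophenyl did not keep its size on the second core, where it gave a 1.6-fold lower number from compound 3 to compound 4 (0.21 log units; within the scatter), and the two steps differ: the same change on two cores in this assay, a 5.1-fold lower number (0.70 log units; beyond the scatter) from compound 1 to compound 2 and a 1.6-fold lower number (0.21 log units; within the scatter) from compound 3 to compound 4, 3.1-fold (0.50 log units) apart, beyond the scatter of two such steps Chloro in place of methyl on an aromatic carbon separates compound 1 and compound 3 by no more than the scatter, yet with 2,4-difluorophenyl present it gives a 3.2-fold higher number from compound 2 to compound 4 (0.50 log units; beyond the scatter), and this contrast appears as well: the same change on two cores in this assay, a 1.0-fold higher number (0.00 log units; within the scatter) from compound 1 to compound 3 and a 3.2-fold higher number (0.50 log units; beyond the scatter) from compound 2 to compound 4, 3.1-fold (0.50 log units) apart, beyond the scatter of two such steps Within these four compounds, then, the size of each change depends on the other group present, so neither can be carried to a new core as a fixed increment, though the direction of the difluorophenyl step is not established on the second core, and the data do not show why the two groups interact.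

The compounds shown leave open whether this dependence extends to other groups on the aromatic carbon, such as methoxy or nitrile. They also leave open how an amine or a carboxylic acid in place of the 2,4-difluorophenyl group would behave on either core.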